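Swapping a saturated ring for an aromatic one on the amide

The source may hold more compounds than are shown below. What is called first, only, known or untested is meant among the compounds shown, and "the series" means these compounds.

In an assay on HEK293 cells for positive allosteric modulation of metabotropic glutamate receptor 5 (Homo sapiens), read by FLIPR (on this read-out lower numbers stand for an effect already at smaller amounts and higher numbers for an effect only at larger amounts of compound), compound 3 `O=C(C1CCC(F)(F)CC1)N1CC(c2nc(-c3cccc(F)c3)no2)C1` gives 520 nM, the second highest of three numbers. Its nearest neighbour is compound 1 `O=C(C1CCCCC1)N1CC(c2nc(-c3cccc(F)c3)no2)C1`, which gives 1000 nM; the change is a 1.9-fold lower number from compound 1 to compound 3 (0.28 log units; within the scatter). Furthest away is compound 2 `O=C([C@H]1CC2CCC1C2)N1CC(c2nc(-c3cccc(F)c3)no2)C1` with 72 nM, a gap of a 7.2-fold higher number from compound 2 to compound 3 (0.86 log units; beyond the scatter). Compound 4 `O=C(c1ccc(F)c(F)c1)N1CC(c2nc(-c3cccc(F)c3)no2)C1` carries 3,4-difluorophenyl in place of 4,4-difluorocyclohexyl on a carbonyl carbon. Going by the values given here, every measured step so far exchanged one saturated ring for another on that carbonyl carbon: a 14-fold lower number from compound 1 to compound 2 (1.14 log units; beyond the scatter), while a 1.9-fold lower number from compound 1 to compound 3 (0.28 log units; within the scatter). Among the compounds with values here, no measured step places an aromatic ring there, so the direction is open; the spread seen shows this position can move the number considerably. Compound 4 is expected to give 600 nM, within 150 nM to 2500 nM, an estimated step of a 1.2-fold higher number from compound 3 to compound 4 (0.06 log units; within the scatter) in this assay.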

Compound 4, half-maximal effective concentration: 3200 nM
Compound 4: middle estimate off by 5.3-fold (0.73 log units), on the low side; the whole stated range lies below it.
By their numbers in this assay, from the lowest: compound 2; then compounds 3 and 1 (each within the scatter of the next); then compound 4.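

In this assay an aromatic ring on this carbonyl carbon gives the highest number of the four compounds: (a 6.2-fold higher number from compound 3 to compound 4 (0.79 log units; beyond the scatter)) and (a 3.2-fold higher number from compound 1 to compound 4 (0.51 log units; beyond the scatter)) and (a 44-fold higher number from compound 2 to compound 4 (1.65 log units; beyond the scatter)). All three saturated rings give lower numbers than 3,4-difluorophenyl, and 4,4-difluorocyclohexyl does so with the same count of heavy atoms, so ring type matters here, not only ring size. No measurement shown explains this rise.

On these data alone, with a single aromatic example, it stays open whether the rise holds for aromatic rings in general. An unsubstituted phenyl or a pyridine ring on this carbonyl carbon could settle that.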